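The source may hold more compounds than are shown below. What is called first, only, known or untested is meant among the compounds shown, and "the series" means these compounds.

Measured so far:
compound 1 `CC(C)Cc1ccc(C(C)c2n[nH]c(=S)n2N)cc1`: "not active" (no number reported) in a functional assay on FOCUS cells (Homo sapiens) for inhibition, read by sulforhodamine B assay, with a stated time of 72 h; on this read-out higher numbers stand for weaker inhibition and lower numbers for stronger inhibition
compound 2 `CC(c1ccc(-c2ccccc2)c(F)c1)c1nnc2n1N=C(c1ccc(Cl)cc1Cl)CS2`: 5400 nM
compound 3 `COc1ccc(C2=Nn3c(nnc3C(C)c3ccc(-c4ccccc4)c(F)c3)SC2)cc1`: 4400 nM

Compound 2 holds the higher of the two numbers reported; its nearest neighbour is compound 3, with a 1.2-fold lower number from compound 2 to compound 3 (0.09 log units; within the scatter), a step within the scatter. For compound 1 no number is reported. Compound 4 `CC(c1ccc(-c2ccccc2)c(F)c1)c1nnc2n1N=C(c1ccc([N+](=O)[O-])cc1)CS2` differs from compound 2 by 4-nitrophenyl in place of 2,4-dichlorophenyl on a carbon with a double bond to nitrogen. For the measured compounds named here, the only measured step at the same place is a 1.2-fold lower number from compound 2 to compound 3 (0.09 log units; within the scatter), which stayed within the scatter, and nothing else bears on the exchange. Accordingly no step beyond the scatter is expected in this assay; the expected step is a 1.1-fold lower number from compound 2 to compound 4 (0.03 log units; within the scatter). Compound 4 is therefore estimated at 5000 nM, with a range from 2000 nM to 13000 nM.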

Compound 4, half-maximal inhibitory concentration: 3500 nM
Beside the measured number, compound 4's estimate is 1.4-fold (0.15 log units) above it; measured number inside the range.
By their numbers in this assay, from the lowest: compounds 4, 3 and 2 (each within the scatter of the next).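

In this assay, 4-nitrophenyl in place of 2,4-dichlorophenyl gives a 1.5-fold lower number from compound 2 to compound 4 (0.19 log units; within the scatter), and nitro in place of methoxy on an aromatic carbon gives a 1.3-fold lower number from compound 3 to compound 4 (0.10 log units; within the scatter). For the compounds shown here, a nitro-bearing aryl group thus joins the dichloro and methoxy ones at this carbon, and no step among compound 2, compound 3 and compound 4 leaves the scatter. Nothing available explains this flatness.

Still open, as far as these compounds go, is whether an amine or a carboxylic acid on this phenyl ring would move the number beyond the scatter. Also open, from the compounds shown here alone, is whether a small alkyl group in place of the whole aryl ring would do so.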